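A few compounds are considered here, and "the series" means these few. Any claim that something is new, unique, unknown or untested is made for them only; others in the source may bear on it.

Values in a functional assay on PC-3 cells (Homo sapiens) for cytotoxicity, read by MTT assay, with a stated time of 72 h (on this read-out higher numbers stand for weaker inhibition and lower numbers for stronger inhibition), for the three measured compounds:

compound 1 `O=C(Nc1ccc(Oc2ccnc3[nH]ccc23)cc1)c1cc(-c2ccc(Br)cc2)ncn1`: 2610 nM
compound 2 `Cc1ccc(-c2cc(C(=O)Nc3ccc(Oc4ccnc5[nH]ccc45)cc3)ncn2)cc1`: 9880 nM
compound 3 `O=C(Nc1ccc(Oc2ccnc3[nH]ccc23)c(F)c1)c1cc(-c2ccc(Br)cc2)ncn1`: 11300 nM

Compound 4 `Cc1ccc(-c2cc(C(=O)Nc3ccc(Oc4ccnc5[nH]ccc45)c(F)c3)ncn2)cc1` is not yet measured. Compound 4 differs from compound 3 by methyl in place of bromo on an aromatic carbon. The same change, made once before among these compounds, takes compound 1 to compound 2: methyl in place of bromo on an aromatic carbon. In this assay that step read a 3.8-fold higher number from compound 1 to compound 2 (0.58 log units; beyond the scatter). The two cores on which the change is made differ by fluoro in place of hydrogen on an aromatic carbon, and that difference read a 4.3-fold higher number from compound 1 to compound 3 (0.64 log units; beyond the scatter). Compound 3 thus carries the highest number of the three; against compound 2 the gap is within the scatter, so no order between those two is claimed.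

Among the measured compounds shown here, from compound 3 to compound 4 a step of about the size of the earlier one is expected, a 3.4-fold higher number from compound 3 to compound 4 (0.53 log units; beyond the scatter), resting on the single measured instance a 3.8-fold higher number from compound 1 to compound 2 (0.58 log units; beyond the scatter) with the change repeated at the same place. Compound 3 already gives 11300 nM, the starting point from which that step is counted. For compound 4 in this assay the estimate is 38000 nM, expected to lie between 15000 nM and 90000 nM.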

Compound 4, half-maximal inhibitory concentration: 24900 nM
The estimate for compound 4 lay 1.5-fold (0.18 log units) above the measured number; low and high end bracket the measured number.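

The change from 4-bromophenyl to 4-methylphenyl carries over to the fluoro-bearing core in this assay, with a 2.2-fold higher number from compound 3 to compound 4 (0.34 log units; beyond the scatter), and the two instances do not differ in size beyond the scatter: the same change on two cores in this assay, a 3.8-fold higher number (0.58 log units; beyond the scatter) from compound 1 to compound 2 and a 2.2-fold higher number (0.34 log units; beyond the scatter) from compound 3 to compound 4, 1.7-fold (0.23 log units) apart, within the scatter of two such steps

Read the other way round, fluoro in place of hydrogen also carries over from the bromo to the methyl compounds, with a 2.5-fold higher number from compound 2 to compound 4 (0.40 log units; beyond the scatter): the same change on two cores in this assay, a 4.3-fold higher number (0.64 log units; beyond the scatter) from compound 1 to compound 3 and a 2.5-fold higher number (0.40 log units; beyond the scatter) from compound 2 to compound 4, 1.7-fold (0.23 log units) apart, within the scatter of two such steps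

Within these four compounds the two changes thus behave as independent steps in the same direction, but this rests on one pair of cores and one pair of groups, and it shows neither that the agreement extends to other cores nor why either change raises the number.

The compounds shown leave open how an amine, a carboxylic acid or a longer chain would read in place of bromo on that aromatic carbon. They also leave open whether any group there would give a lower number than compound 1 does.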